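A few compounds are considered here, and "the series" means these few. Any claim that something is new, unique, unknown or untested is made for them only; others in the source may bear on it.

Measured so far in a functional assay on the whole organism (Tail, strain ICR) with Mus musculus as the target, in the tail flick test, with a stated time of 150 min, at a dose of 25 umol/kg by the oral route; on this read-out lower numbers stand for a weaker effect and higher numbers for a stronger effect at the one dose given:
Compound 1, `O=C(CN(c1ncnc2c1ncn2C1CCCCO1)C1CC1)N[C@@H](CCC(=O)OCc1ccccc1)C(=O)OCc1ccccc1`, gives 14.1%.
Compound 2, `C[C@@H](O)[C@H](NC(=O)CN(c1ncnc2c1ncn2C1CCCCO1)C1CC1)C(=O)OCc1ccccc1`, gives 6.53%.
Compound 3, `CC(C)(C)OC(=O)NCCCC[C@H](NC(=O)CN(c1ncnc2c1ncn2C1CCCCO1)C1CC1)C(=O)OCc1ccccc1`, gives 17.2%.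

Within the data shown here, compound 3 has the highest of the three numbers, yet the step of a number 3.1 percentage points higher from compound 1 to compound 3 (within the scatter) is within the scatter, and only the step of a number 10.7 percentage points higher from compound 2 to compound 3 (beyond the scatter) is a real, if modest, gain. Compound 4, `CSCC[C@H](NC(=O)CN(c1ncnc2c1ncn2C1CCCCO1)C1CC1)C(=O)OCc1ccccc1`, differs from compound 3 in one place: methylsulfanyl in place of 2-((tert-butoxycarbonyl)amino)ethyl on a saturated chain carbon, three bonds along the chain from an amide-type nitrogen and a carbonyl carbon. Both earlier steps touched this same side chain and stayed small, so a small change is the natural expectation. Since compound 4 loses the larger group of compound 3, a modest drop is expected: a number 6.2 percentage points lower from compound 3 to compound 4 (within the scatter), likely within the scatter. For compound 4 the estimated value in this assay is 11%, with a range from 3% to 20%.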

Compound 4, a percentage reported as activity, at one dose (the size of the read-out at that dose, not a potency): 17.5%
Estimate against measurement, compound 4: 6.5 percentage points below; measured number inside the range.
By their numbers in this assay, from the lowest: compounds 2, 1, 3 and 4 (each within the scatter of the next, the first and the last beyond it).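

In this assay, exchanging the 10 heavy atoms of 2-((tert-butoxycarbonyl)amino)ethyl for the 2 of methylsulfanyl gives a number 0.3 percentage points higher from compound 3 to compound 4 (within the scatter), so this much smaller group costs nothing measurable at this place. The other comparisons give a number 3.4 percentage points higher from compound 1 to compound 4 (within the scatter) and, against the 1-hydroxyethyl side chain, a number 11 percentage points higher from compound 2 to compound 4 (beyond the scatter). Nothing available explains these results.

As far as these compounds go, whether a free amine or a carboxylic acid on this side chain would lift the read-out clearly remains open. A single dose also leaves potency unknown.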